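Triazole ethers in THP-1 growth inhibition: compounds 1 to 4

The compounds below may be only part of what the source reports. "The series", "measured", "known", "first", "only" and "open" are said of these compounds alone.

Measured so far in an ADME assay on THP-1 cells (Homo sapiens) for inhibition, read by MTT assay, with a stated time of 48 h; on this read-out higher numbers stand for weaker inhibition of growth and lower numbers for stronger inhibition of growth:
compound 1, `Clc1cccc(Cn2cc(COc3ccccc3)nn2)c1`: 14.6 ug/mL
compound 2, `Brc1ccc(Cn2cc(COc3ccccc3)nn2)cc1`: 16.2 ug/mL
compound 3, `Clc1ccc(OCc2cn(Cc3cccc(Cl)c3)nn2)cc1`: 20.9 ug/mL

Compound 2 differs from compound 1 by 4-bromophenyl in place of 3-chlorophenyl on a saturated chain carbon bound to an aromatic nitrogen; the step of a 1.1-fold higher number from compound 1 to compound 2 (0.05 log units; within the scatter). Compound 3 differs from compound 1 by chloro in place of hydrogen on an aromatic carbon; the step of a 1.4-fold higher number from compound 1 to compound 3 (0.16 log units; within the scatter). Compound 3 and compound 2 are within the scatter of each other in this assay. All three numbers lie close together.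

Compound 4, `Clc1ccc(OCc2cn(Cc3ccc(Br)cc3)nn2)cc1`, has not been measured. It differs from compound 3 by 4-bromophenyl in place of 3-chlorophenyl on a saturated chain carbon bound to an aromatic nitrogen. Within the data shown here, this is the same change as the one from compound 1 to compound 2, at the same place, and the two pairs differ only in their cores as described for compound 1 and compound 3. Among the measured compounds shown here, the only measured pair showing this change gives a 1.1-fold higher number from compound 1 to compound 2 (0.05 log units; within the scatter). Resting on that single measured pair alone, a step of about the same small size is expected here in this assay, namely a 1.1-fold higher number from compound 3 to compound 4 (0.04 log units; within the scatter). On this basis compound 4 is estimated at 23 ug/mL in this assay, likely between 14 ug/mL and 38 ug/mL.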

Compound 4, concentration for 50% growth inhibition: 52.9 ug/mL
Beside the measured number, compound 4's estimate is 2.3-fold (0.36 log units) below it; the whole stated range lies below it.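

In this assay, 4-bromophenyl in place of 3-chlorophenyl on a saturated chain carbon bound to an aromatic nitrogen gives a 2.5-fold higher number from compound 3 to compound 4 (0.40 log units; beyond the scatter), and chloro in place of hydrogen on an aromatic carbon gives a 3.3-fold higher number from compound 2 to compound 4 (0.51 log units; beyond the scatter). With a single pair on each core, the 4-bromophenyl change cannot be called dependent on the core, nor can it be shown to carry over unchanged, since the two steps do not separate: the same change on two cores in this assay, a 1.1-fold higher number (0.05 log units; within the scatter) from compound 1 to compound 2 and a 2.5-fold higher number (0.40 log units; beyond the scatter) from compound 3 to compound 4, 2.3-fold (0.36 log units) apart, within the scatter of two such steps. The chloro change reads the same way, so the two changes cannot be said to act together or independently on these four compounds: the same change on two cores in this assay, a 1.4-fold higher number (0.16 log units; within the scatter) from compound 1 to compound 3 and a 3.3-fold higher number (0.51 log units; beyond the scatter) from compound 2 to compound 4, 2.3-fold (0.36 log units) apart, within the scatter of two such steps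

The 4-bromophenyl change alters the halogen and its place on the ring together, and the compounds shown leave open which of the two accounts for the steps. Also open, as far as these compounds go, is how an amine or a carboxylic acid would behave in place of chloro on an aromatic carbon.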